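Chloro in Place of Bromo on the Chain Carbon

A few compounds are considered here, and "the series" means these few. Any claim that something is new, unique, unknown or untested is made for them only; others in the source may bear on it.

Compound 1 `C=C(F)C(=O)Nc1cc(Nc2nccc(-c3cn(C)c4ccccc34)n2)c(OC)cc1N(C)CCN(C)C`: 2500 nM
Compound 2 `C=C(Br)C(=O)Nc1cc(Nc2nccc(-c3cn(C)c4ccccc34)n2)c(OC)cc1N(C)CCN(C)C`: 1060 nM

In a functional assay on A-431 cells (Homo sapiens) for antiproliferative activity, read by sulforhodamine B assay, with a stated time of 72 h (a higher number here means a weaker inhibitor, a lower number a stronger inhibitor), compound 2 stands at the lowest of the two numbers shown, and the only measured step is a 2.4-fold lower number from compound 1 to compound 2 (0.37 log units; beyond the scatter). Compound 3 `C=C(Cl)C(=O)Nc1cc(Nc2nccc(-c3cn(C)c4ccccc34)n2)c(OC)cc1N(C)CCN(C)C` differs from compound 2 in one place: chloro in place of bromo on a double-bonded chain carbon bound to a carbonyl carbon. That single earlier step, which exchanged one halogen for another at the same place, is all that bears on this change, and it was modest. A small step is therefore expected, a 1.3-fold higher number from compound 2 to compound 3 (0.12 log units; within the scatter), with direction uncertain. Compound 3 is estimated at 1400 nM, expected between 700 nM and 2800 nM.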

Compound 3, half-maximal inhibitory concentration: 1550 nM
Compound 3: the middle estimate sits 1.1-fold (0.04 log units) below what was measured; low and high end bracket the measured number.
By their numbers in this assay, from the lowest: compounds 2, 3 and 1 (each within the scatter of the next, the first and the last beyond it).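

In this assay the chloro compound adds a middle point that cannot be separated from either halogen neighbour: a 1.5-fold higher number from compound 2 to compound 3 (0.17 log units; within the scatter) and a 1.6-fold lower number from compound 1 to compound 3 (0.21 log units; within the scatter) are both within the scatter. Only the fluoro and bromo compounds, compound 1 and compound 2, lie beyond the scatter of each other, so swapping one halogen for another at this place changes the result little in these compounds. No measurement here accounts for this pattern. Still open, as far as these compounds go, is what a plain hydrogen, a methyl or an iodo group would give on the same double-bonded chain carbon.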